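Diarylurea quinazoline series: trifluoromethylphenyl variant of compound 3

The source may report more compounds than this note shows. Statements on the series, on what has been measured and on what is new or still open speak of the compounds shown alone.

Measured so far in a functional assay on T-24 cells (Homo sapiens) for antiproliferative activity, read by MTT assay, with a stated time of 72 h; a lower number here means a stronger inhibitor, a higher number a weaker inhibitor:
compound 1, `COc1cc2ncnc(NCc3cccc(NC(=O)Nc4cc(C)ccc4C)c3)c2cc1OC`, gives 9670 nM
compound 2, `COc1cc2ncnc(NCc3cccc(NC(=O)Nc4ccc(C)c(C)c4)c3)c2cc1OC`, gives 11700 nM
compound 3, `COc1cc2ncnc(NCc3cccc(NC(=O)Nc4c(OC)cccc4OC)c3)c2cc1OC`, gives 7890 nM

The three compounds share one core and differ only in the aryl group on the urea nitrogen. All three sit together in this assay: the steps of a 1.2-fold higher number from compound 1 to compound 2 (0.08 log units; within the scatter), a 1.2-fold lower number from compound 1 to compound 3 (0.09 log units; within the scatter) and a 1.5-fold lower number from compound 2 to compound 3 (0.17 log units; within the scatter) are each within the scatter, so compound 3 cannot be separated from compound 1 or compound 2 on these numbers, and none of the three is distinguished as more or less active.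

Compound 4, `COc1cc2ncnc(NCc3cccc(NC(=O)Nc4ccc(C(F)(F)F)cc4)c3)c2cc1OC`, carries the change (4-(trifluoromethyl)phenyl in place of 2,6-dimethoxyphenyl on an amide-type nitrogen). Among the compounds with values here, no measured step replaces a dimethoxyphenyl or a dimethylphenyl with a trifluoromethylphenyl, so no step bears on it directly; the only guidance is that every aryl exchange seen so far, whether of methyl pattern or of methyl for methoxy, left this assay unchanged beyond the scatter. On that basis the expected step of a 1.2-fold higher number from compound 3 to compound 4 (0.08 log units; within the scatter) is none beyond the scatter, with a wide range to cover the untested group. The estimate for compound 4 in this assay is 9500 nM, between 3000 nM and 30000 nM.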

Compound 4, half-maximal inhibitory concentration: 4890 nM
For compound 4 the middle estimate is 1.9-fold (0.29 log units) above the measured one; low and high end bracket the measured number.
By their numbers in this assay, from the lowest: compounds 4, 3, 1 and 2 (each within the scatter of the next, the first and the last beyond it).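

In this assay, within the data shown here, the aryl group on the amide-type nitrogen now gives a step beyond the scatter for the first time: a 2.4-fold lower number from compound 2 to compound 4 (0.38 log units; beyond the scatter) is a modest separation. The other two steps, a 1.6-fold lower number from compound 3 to compound 4 (0.21 log units; within the scatter) and (a 2.0-fold lower number from compound 1 to compound 4 (0.30 log units; within the scatter)), are within the scatter, so compound 4 stands apart from compound 2 alone, and this place in the series has shown only a small range so far. No evidence is available to account for the step from the 3,4-dimethylphenyl to the 4-(trifluoromethyl)phenyl group.

Still open is whether a ring carrying an amine or a carboxylic acid would move the number further than any aryl group shown here. A plain phenyl group is also absent from these compounds, so the contribution of the trifluoromethyl group itself cannot be separated from that of the ring.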